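Trimethoxyphenyl for Phenyl: Tolerated Concentration on Dog Kidney Cells

A few compounds are considered here, and "the series" means these few. Any claim that something is new, unique, unknown or untested is made for them only; others in the source may bear on it.

Compound 1 `CSc1nc(NCCCCNc2ccnc3cc(Cl)ccc23)c(C#N)c(-c2ccccc2)n1`: 20000 nM
Compound 2 `CSc1nc(-c2ccccc2)c(C#N)c(N2CCN(c3ccnc4cc(Cl)ccc34)CC2)n1`: > 100000 nM

Of the compounds shown here, two have been measured in an ADME assay on MDCK cells (Canis lupus familiaris) for cytotoxicity, read by microscopy; a higher number here means that more compound is tolerated, a lower number that less compound is tolerated. Going by the values given here, compound 1 gives 20000 nM, the only outright number among the results so far. Compound 2 gives only a limit of the assay, (the limit of > 100000 nM in this assay, at which 1 of the 2 values shown sits), and no number. Compound 1 therefore stands alone as the single measured point against which the next compound can be judged.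

Compound 3 `COc1cc(-c2nc(SC)nc(NCCCCNc3ccnc4cc(Cl)ccc34)c2C#N)cc(OC)c1OC` differs from compound 1 in one place: 3,4,5-trimethoxyphenyl in place of phenyl on an aromatic carbon. Among the compounds with values here, no step between two measured compounds is available to show what such a change does in this assay, so the expected size of the step is taken as none beyond the usual scatter, in no particular direction. Compound 3 is thus estimated at 20000 nM, with a range from 6000 nM to 70000 nM. This estimate means a step of no change at the digits printed from compound 1 to compound 3 (within the scatter).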

Compound 3, minimum cytotoxic concentration: 4000 nM
For compound 3 the middle estimate is 5.0-fold (0.70 log units) above the measured one; measured number below the stated range.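

In this assay, 3,4,5-trimethoxyphenyl in place of phenyl on the aromatic carbon next to the ring nitrogen and ortho to a cyano group gives a 5.0-fold lower number from compound 1 to compound 3 (0.70 log units; beyond the scatter). Going by these compounds alone, this is the first step that can be read between two measured compounds, and it shows that this position is not indifferent in this assay: the change leaves the rest of the molecule as it stands, yet less compound is tolerated. Nothing among the results shown speaks to why the tolerated concentration falls with this change.

On these data alone, it remains open whether all three methoxy groups are needed for this shift, or whether a single methoxy group would give it too. Also open, as far as these compounds go, is what an amine or a carboxylic acid on the phenyl ring would do, and whether the same change would have a similar effect on the core of compound 2.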